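Allyl Out, Nitro In: One Change on Compound 1

This account rests on a few compounds, and the source may have more. Where it says the series, first, only, none or still open, it means among the compounds named here.

Compound 1 `C=CCc1cc(C(=O)N[C@H](C)CCCc2cccnc2)ccc1-c1ccc(OC)c(OC)c1`: 80 nM
Compound 2 `COc1cccc(-c2ccc(C(=O)NCCCCc3cccnc3)cc2)c1`: 280 nM
Compound 3 `O=C(NCCCCc1cccnc1)c1ccc(-c2ccccc2)c(-c2ccccc2)c1`: 5 nM

In an assay (Canis lupus familiaris) for binding affinity to platelet-activating factor receptor (Homo sapiens), read by radioligand binding (a higher number here means a weaker inhibitor, a lower number a stronger inhibitor), compound 1 gives 80 nM, the second highest of the three numbers. Its nearest neighbour is compound 2, whose value of 280 nM is higher by more than the usual scatter. Compound 3, with 5 nM, gives a lower number than compound 1 by a margin well beyond the scatter, so among these three it is the strongest inhibitor.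

Compound 4 `COc1ccc(-c2ccc(C(=O)N[C@H](C)CCCc3cccnc3)cc2[N+](=O)[O-])cc1OC` has not yet been measured. It is derived from compound 1 by one change: nitro in place of allyl on an aromatic carbon. Going by the values given here, no measured pair shows this same change, so nothing here fixes the size of the step. With the shared core and the same amide chain kept, the expectation in this assay is a small step, perhaps toward a somewhat higher number, but not clearly beyond the scatter; the step from compound 1 to compound 4 is estimated as a 1.5-fold higher number from compound 1 to compound 4 (0.18 log units; within the scatter). Compound 4 is thus expected to give about 120 nM, within a range of 40 nM to 400 nM.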

Compound 4, half-maximal inhibitory concentration: 200 nM
For compound 4 the middle estimate is 1.7-fold (0.22 log units) below the measured one; the measured number falls inside the stated range.
By their numbers in this assay, from the lowest: compound 3; then compound 1; then compounds 4 and 2 (each within the scatter of the next).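

Going by these compounds alone, replacing allyl with nitro on this aromatic carbon, ortho to a 3,4-dimethoxyphenyl group, gives a 2.5-fold higher number from compound 1 to compound 4 (0.40 log units; beyond the scatter) in this assay, the first measured step at this position and a modest one. The two groups match in heavy-atom count and each has one double bond outside aromatic rings, yet they differ in their atoms and in hydrogen-bond acceptors, so a matching count alone does not keep the number unchanged. Nothing measured here gives a reason for this step.

As far as these compounds go, what an amine, a carboxylic acid or a longer chain on this same carbon would do remains open. So does whether this swap would give a step of similar size with a different amide chain.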